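Isobutyl carbamate in place of the tert-butyl carbamate

A few compounds are considered here, and "the series" means these few. Any claim that something is new, unique, unknown or untested is made for them only; others in the source may bear on it.

Two analogues built on one shared core have been characterised in an assay on CHO-K1 cells for displacement of a labelled ligand from prostaglandin E2 receptor EP1 subtype (Homo sapiens); on this read-out higher numbers stand for weaker inhibition and lower numbers for stronger inhibition. Compound 1 `Cc1cc(NC(=O)c2c(F)cccc2F)nn1Cc1cc(Cl)ccc1OCc1ccccc1` gives 12.6 nM in this assay. Compound 2 `Cc1cc(NC(=O)OC(C)(C)C)nn1Cc1cc(Cl)ccc1OCc1ccccc1`, which carries tert-butoxy in place of the 2,6-difluorophenyl on the carbonyl carbon, gives 25.1 nM in this assay; the two numbers sit together, separated by a 2.0-fold higher number from compound 1 to compound 2 (0.30 log units; within the scatter), and compound 2 is the one at the top of this pair. Compound 3 `Cc1cc(NC(=O)OCC(C)C)nn1Cc1cc(Cl)ccc1OCc1ccccc1` has the same atoms as compound 2, joined differently: isobutyl in place of tert-butyl on an oxygen next to a carbonyl group. For the measured compounds named here, no measured step alters the alkyl group on that oxygen, so the single step available, a 2.0-fold higher number from compound 1 to compound 2 (0.30 log units; within the scatter), touches this change only indirectly, and it shows that even a larger exchange at the carbonyl carbon left the number within the scatter. The step from the tert-butyl to the isobutyl carbamate is expected to be no larger than the scatter, which is a 1.0-fold lower number from compound 2 to compound 3 (0.00 log units; within the scatter). Compound 3 is accordingly estimated at 25 nM in this assay, with a range from 8 nM to 80 nM.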

Compound 3, half-maximal inhibitory concentration: 25.1 nM
Compound 3: middle estimate off by 1.0-fold (0.00 log units), on the low side; low and high end bracket the measured number.
By their numbers in this assay, from the lowest: compounds 1, 2 and 3 (each within the scatter of the next).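

The exchange of tert-butyl for isobutyl on an oxygen next to a carbonyl group, the first measured alteration of that alkyl group, gives no change at the digits printed from compound 2 to compound 3 (within the scatter) in this assay and so does not separate these two arrangements of the same atoms. The isobutyl carbamate also lies close to the 2,6-difluorophenyl amide, with a 2.0-fold higher number from compound 1 to compound 3 (0.30 log units; within the scatter) on the same read-out, so a second alkoxy group on the carbonyl carbon, like tert-butoxy before it, stays within the scatter of the aromatic group. No measurement at hand bears on why these groups give such similar numbers.

The compounds shown leave open how far the alkyl group on that oxygen can depart from these two before the number moves, for instance with a longer chain such as n-hexyl, a cyclohexyl ring, or a chain ending in an amine or a carboxylic acid. Also open, as far as these compounds go, is whether the same picture would hold if a nitrogen took the place of the carbamate oxygen, as in a urea.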